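Bringing a Hydroxy Group Back Beside a Bromine

This account rests on a few compounds, and the source may have more. Where it says the series, first, only, none or still open, it means among the compounds named here.

compound 1 `Cn1c(=O)c(=O)n(C2CCCC2)c2nc(N/N=C/c3ccc(O)cc3)ncc21` gives > 100000 nM (a limit)
compound 2 `Cc1cc(C)c(/C=N/Nc2ncc3c(n2)n(C2CCCC2)c(=O)c(=O)n3C)c(C)c1` gives 12000 nM
compound 3 `Cn1c(=O)c(=O)n(C2CCCC2)c2nc(N/N=C/c3ccc(F)cc3Br)ncc21` gives 6590 nM

In a functional assay on A549 cells (Homo sapiens) for antiproliferative activity, read by MTT assay (on this read-out lower numbers stand for stronger inhibition and higher numbers for weaker inhibition), the value of compound 1 is a limit (> 100000 nM). Compound 3 gives 6590 nM and cannot be told apart from its nearest neighbour (a 1.8-fold lower number from compound 2 to compound 3 (0.26 log units; within the scatter)).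

Compound 4 `Cn1c(=O)c(=O)n(C2CCCC2)c2nc(N/N=C/c3ccc(O)c(Br)c3)ncc21` changes one group on a carbon with a double bond to nitrogen: 3-bromo-4-hydroxyphenyl in place of 2-bromo-4-fluorophenyl (3-bromo-4-hydroxyphenyl in place of 2-bromo-4-fluorophenyl on a carbon with a double bond to nitrogen). The hydroxy group recalls compound 1, and replacing 4-hydroxyphenyl gave clear steps (an at least 8.3-fold lower number from compound 1 to compound 2 (0.92 log units; beyond the scatter)) and (an at least 15-fold lower number from compound 1 to compound 3 (1.18 log units; beyond the scatter)). The bromine stays, so only part of the latter step is expected to be undone, towards a higher number (a 3.8-fold higher number from compound 3 to compound 4 (0.58 log units; beyond the scatter)). For compound 4 the estimated value is 25000 nM (expected range 7000 nM to 90000 nM).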

Compound 4, half-maximal inhibitory concentration: 12800 nM
Compound 4: the middle estimate sits 2.0-fold (0.29 log units) above what was measured; measured number inside the range.
By their numbers in this assay, from the lowest: compounds 3, 2 and 4 (each within the scatter of the next). At a limit, above all of these: compound 1.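

In this assay, bromo added to the 4-hydroxyphenyl group gives an at least 7.8-fold lower number from compound 1 to compound 4 (0.89 log units; beyond the scatter), so a hydroxy group and a measurable number can go together. As far as these compounds go, how large that step really is stays unknown, since compound 1 stands at a limit: the limit of > 100000 nM in this assay, at which 1 of the 4 values shown sits. The other two comparisons cannot be told apart from no change: a 1.9-fold higher number from compound 3 to compound 4 (0.29 log units; within the scatter) and a 1.1-fold higher number from compound 2 to compound 4 (0.03 log units; within the scatter).

From the compounds shown here alone, whether chloro or methoxy could stand in for the bromo of compound 4 remains open. So does the effect of an amine in place of its hydroxy group.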